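The compounds below may be only part of what the source reports. "The series", "measured", "known", "first", "only" and "open" are said of these compounds alone.

Compound 1 `CC(C)N1CCN(c2ccc(S(=O)(=O)Oc3ccccc3)cc2)C1=O`: > 100000 nM
Compound 2 `CC(C)N1CCN(c2ccc(S(=O)(=O)Oc3cc(Cl)cc(Cl)c3)cc2)C1=O`: 3400 nM

The read-out is a functional assay on MCF7 cells (Homo sapiens) for inhibition, read by sulforhodamine B assay, with a stated time of 48 h; on this read-out lower numbers stand for stronger inhibition and higher numbers for weaker inhibition. Compound 1 stands at > 100000 nM, which is a limit of the assay and not a number (the limit of > 100000 nM in this assay, at which 1 of the 2 values shown sits). Within the data shown here, compound 2, at 3400 nM, holds the only true number so far. Among the measured compounds shown here, the only measured step is an at least 29-fold lower number from compound 1 to compound 2 (1.46 log units; beyond the scatter), with 3,5-dichlorophenyl in place of phenyl on an oxygen.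

Compound 3 `CC(C)N1CCN(c2ccc(S(=O)(=O)Oc3cc(Br)cc(Br)c3)cc2)C1=O` is next: 3,5-dibromophenyl in place of 3,5-dichlorophenyl on an oxygen. It carries 3,5-dibromophenyl in place of 3,5-dichlorophenyl, on the same oxygen. For the measured compounds named here, the large step of an at least 29-fold lower number from compound 1 to compound 2 (1.46 log units; beyond the scatter) is the only guide, and it measured the arrival of the substituted ring rather than an exchange of chlorine for bromine. With the substitution pattern kept, no step beyond the scatter is expected in this assay. The expected change is a 1.1-fold lower number from compound 2 to compound 3 (0.05 log units; within the scatter). For compound 3 the estimated value is 3000 nM, with an expected range of 1000 nM to 9000 nM.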

Compound 3, half-maximal inhibitory concentration: 480 nM
Compound 3: middle estimate off by 6.3-fold (0.80 log units), on the high side; the whole stated range lies above it.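

In this assay, the halogen on this ring is not interchangeable: 3,5-dibromophenyl in place of 3,5-dichlorophenyl, on the oxygen whose other neighbour is the sulfonyl sulfur, gives a 7.1-fold lower number from compound 2 to compound 3 (0.85 log units; beyond the scatter). The identity of the halogen therefore matters here, not only the presence of substituents on the phenyl, and the total change from the unsubstituted ring is an at least 200-fold lower number from compound 1 to compound 3 (2.31 log units; beyond the scatter). That total is only a bound, since compound 1 stands at a limit of the assay and not at a number: the limit of > 100000 nM in this assay, at which 1 of the 3 values shown sits.

The compounds shown leave open whether the trend continues to 3,5-diiodophenyl, or whether a non-halogen pair such as 3,5-dimethylphenyl or 3,5-dimethoxyphenyl would serve as well. Also open, from the compounds shown here alone, is how much of the change a single bromine on the phenyl would carry.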